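The compounds below may be only part of what the source reports. "The series", "measured", "known", "first", "only" and "open" are said of these compounds alone.

Compound 1 `O=C(NCCO)c1c(N2CCCC2)cc(-c2ccccc2)oc1=O` carries the shared core, and in an ADME assay on Vero cells (Chlorocebus sabaeus) for cytotoxicity, read by MTT assay, with a stated time of 2 days (on this read-out higher numbers stand for lower toxicity in this test and lower numbers for higher toxicity in this test), compound 1 gives 30 ug/mL. Compound 2 `O=C(Nc1ccccc1)c1c(N2CCCC2)cc(-c2ccccc2)oc1=O` gives 37.5 ug/mL in this assay, and compound 3 `Cc1ccc(NC(=O)c2c(N3CCCC3)cc(-c3ccccc3)oc2=O)cc1` gives 56.5 ug/mL. On these three numbers compound 1 has the lowest, though all three sit within the scatter of one another: the nearest is compound 2 with a 1.3-fold higher number from compound 1 to compound 2 (0.10 log units; within the scatter), the furthest compound 3 with a 1.9-fold higher number from compound 1 to compound 3 (0.27 log units; within the scatter), and between the other two lies a 1.5-fold higher number from compound 2 to compound 3 (0.18 log units; within the scatter). Each of these steps changes only the group on the amide-type nitrogen.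

Compound 4 `O=C(NCCO)c1c(N2CCCCC2)cc(-c2ccccc2)oc1=O` differs from compound 1 in a single place: piperidin-1-yl in place of pyrrolidin-1-yl on an aromatic carbon. Among the measured compounds shown here, no measured step touches this part of the molecule, so the three steps bear on it only indirectly, by showing that small changes elsewhere on the same core left the number within the scatter. There is no evidence here that the ring exchanged in compound 4 moves the number either way. The expectation for compound 4 is therefore a step of no change at the digits printed from compound 1 to compound 4 (within the scatter) in this assay, no larger than the scatter. Compound 4 is estimated at 30 ug/mL, with a range from 15 ug/mL to 60 ug/mL.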

Compound 4, half-maximal cytotoxic concentration: 52.5 ug/mL
For compound 4 the middle estimate is 1.8-fold (0.24 log units) below the measured one, and the stated range covers the measured number.
By their numbers in this assay, from the lowest: compounds 1, 2, 4 and 3 (each within the scatter of the next).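

The exchange of pyrrolidin-1-yl for piperidin-1-yl is the first change shown at this aromatic carbon, the one opposite the ring oxygen, and in this assay it gives a 1.8-fold higher number from compound 1 to compound 4 (0.24 log units; within the scatter). For this one pair, then, a six-membered non-aromatic ring can take the place of the five-membered one at this position without the number leaving the usual scatter, so the earlier indirect reading now has a direct measurement behind it. Nothing shown here gives a measured property that could explain the number for either ring.

As far as these compounds go, this reading rests on a single pair with the 2-hydroxyethyl group on the amide-type nitrogen, so it remains open whether the same ring exchange would stay within the scatter with the phenyl group of compound 2 or the 4-methylphenyl group of compound 3. Also open, from the compounds shown here alone, is how this assay would read with other groups at this position, such as morpholin-4-yl, which adds an oxygen to the ring, or an open-chain dimethylamino group.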